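The source may report more compounds than this note shows. Statements on the series, on what has been measured and on what is new or still open speak of the compounds shown alone.

Compound 1, `CCN(CC)Cc1cc(Br)c(S(C)(=O)=O)cc1C(=O)N=C(N)N`, gives 9500 nM in a functional assay for inhibition of sodium/hydrogen exchanger (Oryctolagus cuniculus); on this read-out higher numbers stand for weaker inhibition and lower numbers for stronger inhibition.
Compound 2, `Cc1ccc(-c2ccc(C(=O)N=C(N)N)cc2S(C)(=O)=O)cc1`, gives 100 nM in this assay.
Compound 3, `Cc1cc(-c2ccc(F)cc2)c(S(C)(=O)=O)cc1C(=O)N=C(N)N`, gives 36 nM in this assay.

Among these three numbers compound 3 stands lowest, which on this read-out means the strongest inhibition of the set. Its nearest neighbour is compound 2, and the gap between the two lies beyond the usual scatter of repeated measurements; compound 1 lies far further away, with much weaker inhibition.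

Compound 4, `Cc1cc(Oc2cccc(Cl)c2)c(S(C)(=O)=O)cc1C(=O)N=C(N)N`, has not yet been measured. It differs from compound 3 in a single place: 3-chlorophenoxy in place of 4-fluorophenyl on an aromatic carbon. Within the data shown here, no measured pair of compounds shows a change of this kind, so there is nothing to rest the size of its effect on directly. With that in mind, a modest step in this assay is expected, more likely toward weaker inhibition than toward stronger, and it may well stay within the scatter. Compound 4 is therefore estimated at 80 nM, with a range from 20 nM to 400 nM. This estimate means an expected step of a 2.2-fold higher number from compound 3 to compound 4 (0.35 log units; beyond the scatter).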

Compound 4, half-maximal inhibitory concentration: 21 nM
Estimate against measurement, compound 4: 3.8-fold (0.58 log units) above, and the stated range covers the measured number.
By their numbers in this assay, from the lowest: compounds 4 and 3 (each within the scatter of the next); then compound 2; then compound 1.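

In this assay, placing 3-chlorophenoxy instead of 4-fluorophenyl on the aromatic carbon ortho to a methylsulfonyl group gives a 1.7-fold lower number from compound 3 to compound 4 (0.23 log units; within the scatter), so the two compounds cannot be told apart. Among these compounds, this is the first sign that this position accepts more than one aromatic group: a ring joined through an oxygen serves as well as a ring joined directly, even with its halogen changed and moved. No measurement here accounts for this match.

As far as these compounds go, the step changes the link, the halogen and its place on the ring all at once, so the share of each stays open. Also open, from the compounds shown here alone, is whether a group without an aromatic ring at this position, such as a primary amine or a carboxylic acid, would hold inhibition at this level.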